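A few compounds are considered here, and "the series" means these few. Any claim that something is new, unique, unknown or untested is made for them only; others in the source may bear on it.

Working notes on the series. Compound 1 `Cc1cccc(NC(=O)c2cc3cc(C)ccc3oc2=O)c1` and compound 2 `Cc1cccc(NC(=O)c2coc3ccc(C)cc3c2=O)c1` carry a methylphenyl on the amide nitrogen, compound 3 `Cc1ccc2occ(C(=O)Nc3cccc(Cl)c3)c(=O)c2c1` a chlorophenyl. In an assay on cells for inhibition of Amine oxidase [flavin-containing] B (Homo sapiens), read by fluorescence and Amplex Red, using microsomes, with a stated time of 15 min (a higher number here means a weaker inhibitor, a lower number a stronger inhibitor), compound 1 gives 7.52 nM, compound 2 gives 17.1 nM, and compound 3 gives 4.2 nM. Compound 3 has the lowest number of the three; its gap to compound 1 is within the scatter, its gap to compound 2 is beyond it. For the measured compounds named here, the one step measured so far in one place is a 4.1-fold lower number from compound 2 to compound 3 (0.61 log units; beyond the scatter).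

Compound 4 `Cc1ccc2occ(C(=O)Nc3ccc(Cl)cc3)c(=O)c2c1` differs from compound 3 by 4-chlorophenyl in place of 3-chlorophenyl on an amide-type nitrogen. Going by the values given here, no measured step bears directly on this change: the step from compound 2 to compound 3 swaps chloro for methyl on the aromatic ring, whereas here the chlorine stays and only its position on the phenyl moves. Among the compounds with values here, the series gives no precedent for moving a substituent around that ring, so no step beyond the scatter is expected in this assay, and the estimated step is a 1.4-fold higher number from compound 3 to compound 4 (0.15 log units; within the scatter). Compound 4 is therefore expected at about 6 nM, with a range from 2 nM to 20 nM in this assay, the uncertainty reflecting the absence of any positional precedent.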

Compound 4, half-maximal inhibitory concentration: 45.4 nM
Compound 4: middle estimate off by 7.6-fold (0.88 log units), on the low side; the measured number lies above the stated range.
By their numbers in this assay, from the lowest: compounds 3 and 1 (each within the scatter of the next); then compound 2; then compound 4.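

In this assay, the phenyl on the amide-type nitrogen proves sensitive to where its chlorine sits: 4-chlorophenyl in place of 3-chlorophenyl, with the same atoms joined differently, gives an 11-fold higher number from compound 3 to compound 4 (1.03 log units; beyond the scatter) and counts as a large step, whereas the swap of methyl for chloro gave the modest 4.1-fold lower number from compound 2 to compound 3 (0.61 log units; beyond the scatter) in the other direction. The 4-chlorophenyl group also compares unfavourably with 3-methylphenyl on the same core, with a 2.7-fold higher number from compound 2 to compound 4 (0.42 log units; beyond the scatter) as a modest step, so that among the three groups on this core, 4-chlorophenyl gives the highest number and 3-chlorophenyl the lowest. Nothing measured in this series accounts for this dependence on the chlorine's place.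

The compounds shown leave open whether methyl on the phenyl shows the same dependence on place as chlorine, and whether 3-chlorophenyl and 4-chlorophenyl differ in the same way on the core of compound 1. They also leave open how a methoxy group, an amine or a carboxylic acid would behave on that phenyl in place of the chlorine.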